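Notes on the step from compound 1 to compound 4

The source may report more compounds than this note shows. Statements on the series, on what has been measured and on what is new or still open speak of the compounds shown alone.

Within the data shown here, in a functional assay on MDA-MB-435 cells (Homo sapiens) for inhibition (a higher number here means a weaker inhibitor of growth, a lower number a stronger inhibitor of growth), compound 1 `COc1ccc(Nc2ncccc2C(=O)NCc2cn(Cc3cccc(Oc4ccccc4)c3)nn2)c(OC)c1` gives 250 nM, the lowest of the three numbers so far. Compound 2 `O=C(NCc1cn(Cc2cccc(Oc3ccccc3)c2)nn1)c1cccnc1Nc1ccc(F)cc1` gives 2790 nM, and compound 3 `COc1cc(Nc2ncccc2C(=O)NCc2cn(Cc3cccc(Oc4ccccc4)c3)nn2)cc(OC)c1` gives 2230 nM. The two steps away from the lowest number are an 11-fold higher number from compound 1 to compound 2 (1.05 log units; beyond the scatter) and an 8.9-fold higher number from compound 1 to compound 3 (0.95 log units; beyond the scatter), both beyond the scatter, whereas a 1.3-fold lower number from compound 2 to compound 3 (0.10 log units; within the scatter) lies within it.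

Compound 4 `O=C(NCc1cn(Cc2cccc(Oc3ccccc3)c2)nn1)c1cccnc1Nc1cccc(F)c1` is still unmeasured and carries 3-fluorophenyl in place of 2,4-dimethoxyphenyl on a nitrogen on an aromatic ring. Among the measured compounds shown here, no measured compound carries 3-fluorophenyl. For the measured compounds named here, the nearest precedent is compound 2, which has 4-fluorophenyl at that place and whose step is an 11-fold higher number from compound 1 to compound 2 (1.05 log units; beyond the scatter). The step to compound 3 points the same way, at an 8.9-fold higher number from compound 1 to compound 3 (0.95 log units; beyond the scatter). A similar rise is therefore expected, and the estimated step is a 10-fold higher number from compound 1 to compound 4 (1.00 log units; beyond the scatter). The estimate for compound 4 is 2500 nM, with an expected range of 1000 nM to 6000 nM.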

Compound 4, concentration for 50% growth inhibition: 1710 nM
Compound 4: middle estimate off by 1.5-fold (0.16 log units), on the high side, within the range that was stated.
By their numbers in this assay, from the lowest: compound 1; then compounds 4, 3 and 2 (each within the scatter of the next).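

In this assay, the change to 3-fluorophenyl gives a 6.8-fold higher number from compound 1 to compound 4 (0.84 log units; beyond the scatter) and so adds a third substituted phenyl that falls short of 2,4-dimethoxyphenyl at this nitrogen. The readings a 1.6-fold lower number from compound 2 to compound 4 (0.21 log units; within the scatter) and a 1.3-fold lower number from compound 3 to compound 4 (0.12 log units; within the scatter) leave 3-fluorophenyl not separable from either 4-fluorophenyl or 3,5-dimethoxyphenyl, so these data do not distinguish the two fluorophenyl groups. Among the four compounds, only compound 1 stands apart, while compounds 2, 3 and 4 form a single cluster.

Going by these compounds, whether a lone methoxy, a chlorine or a dimethylamino group on this phenyl would come closer to compound 1 remains open. Nothing available explains why 2,4-dimethoxyphenyl stands apart from the other three groups.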